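A few compounds are considered here, and "the series" means these few. Any claim that something is new, unique, unknown or untested is made for them only; others in the source may bear on it.

Within the data shown here, in a functional assay on A549 cells (Homo sapiens) for cytotoxicity, read by MTT assay, with a stated time of 72 h (a lower number here means a stronger inhibitor, a higher number a weaker inhibitor), compound 2 (`COc1cc2ncnc(Nc3ccc(F)c(Cl)c3)c2cc1NC(=O)N/N=C/c1ccc(OC)c(OC)c1OC`) gives 32800 nM and sits within the scatter of compound 1 (`COc1cc2ncnc(Nc3ccc(F)c(Cl)c3)c2cc1NC(=O)N/N=C/c1ccc(F)cc1Cl`) at 28200 nM as the only other measured compound. Compound 3 (`COc1cc2ncnc(Nc3ccc(F)c(Cl)c3)c2cc1NC(=O)N/N=C/c1ccc(O)c(Br)c1`) brings the change 3-bromo-4-hydroxyphenyl in place of 2,3,4-trimethoxyphenyl on a carbon with a double bond to nitrogen in which 3-bromo-4-hydroxyphenyl replaces 2,3,4-trimethoxyphenyl on a carbon with a double bond to nitrogen. Among the measured compounds shown here, the one measured step at this place is a 1.2-fold higher number from compound 1 to compound 2 (0.07 log units; within the scatter) and stays within the scatter, so no step beyond the scatter is expected in this assay for this change. For the measured compounds named here, that single step is thin evidence, and no measured compound carries 3-bromo-4-hydroxyphenyl, so the range is kept wide. The estimate is a 1.3-fold lower number from compound 2 to compound 3 (0.12 log units; within the scatter) and is expected to remain inside the scatter. Compound 3 is expected at 25000 nM with an estimated range of 9000 nM to 60000 nM in this read-out.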

Compound 3, half-maximal inhibitory concentration: 28600 nM
The estimate for compound 3 lay 1.1-fold (0.06 log units) below the measured number, and the stated range covers the measured number.
By their numbers in this assay, from the lowest: compounds 1, 3 and 2 (each within the scatter of the next).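

In this assay, 3-bromo-4-hydroxyphenyl on a carbon with a double bond to nitrogen gives a 1.1-fold lower number from compound 2 to compound 3 (0.06 log units; within the scatter) and a 1.0-fold higher number from compound 1 to compound 3 (0.01 log units; within the scatter), so three differently substituted phenyl groups now lie within the scatter of one another. The entering group carries bromine and a hydrogen-bond donor, neither of which appears in the two earlier groups, and it has fewer heavy atoms than 2,3,4-trimethoxyphenyl, yet no step beyond the scatter appears. No supporting measurement is available to explain this flat result.

The hydroxyl and the bromine enter together, so their separate contributions cannot be read. As far as these compounds go, whether a phenyl group carrying an amine or a carboxylic acid, or a non-aromatic group such as a longer alkyl chain, would give a step beyond the scatter at this position remains open.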